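Swapping the Aryl Tail in a Lipoxygenase Series

A few compounds are considered here, and "the series" means these few. Any claim that something is new, unique, unknown or untested is made for them only; others in the source may bear on it.

Of the compounds shown here, three have been tested in an assay for inhibition of Polyunsaturated fatty acid 5-lipoxygenase (Homo sapiens), read by HPLC, with a stated time of 10 min; a lower number here means a stronger inhibitor, a higher number a weaker inhibitor. Compound 1 `Cc1cccc(OCCCOc2ccc(CCC(=O)O)cc2)c1C` was recorded as > 10000 nM, which is a limit of the assay rather than a number. Compound 2 `CCCCC(Sc1ccc(OCCCOc2ccccc2OC)cc1)C(=O)O` likewise gave > 10000 nM, again only a limit. Compound 3 `CCCCC(Sc1ccc(OCCCOc2ccc3ncccc3c2)cc1)C(=O)OCC` gave > 10000 nM, also a limit. Compound 2 therefore cannot be placed on a scale among the others: its result is the limit of > 10000 nM in this assay, at which 3 of the 3 values shown sit, and no measured step between any two of these compounds can be drawn from such limits.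

Compound 4 `CCCCC(Sc1ccc(OCCCOc2cccc(C(C)C)c2)cc1)C(=O)O` differs from compound 2 in one place: 3-isopropylphenyl in place of 2-methoxyphenyl on an oxygen on a saturated carbon. For the measured compounds named here, with no measured step to lean on, the expected step of an at least 1.4-fold lower number from compound 2 to compound 4 (0.15 log units; that floor lies within the scatter) is a cautious guess that leans toward stronger inhibition but may well stay within the scatter, and a further limit is quite possible. The estimate for compound 4 in this assay is expected to be 7000 nM, with a range from 1500 nM to 30000 nM.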

Compound 4, half-maximal inhibitory concentration: 6000 nM
Beside the measured number, compound 4's estimate is 1.2-fold (0.07 log units) above it, within the range that was stated.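

Compound 4 is the first compound here to give a number rather than a limit in this assay, so a change in the group on an oxygen on a saturated carbon can bring this series into readable range, while the others remain at a limit of the assay: the limit of > 10000 nM in this assay, at which 3 of the 4 values shown sit.

Putting 3-isopropylphenyl in place of 2-methoxyphenyl gives an at least 1.6-fold lower number from compound 2 to compound 4 (0.22 log units; that floor lies within the scatter). That figure is only a floor, set by the limit of compound 2; the true step could be larger, yet nothing shown places it beyond the scatter.

This one swap changes both the group and its place on the ring, and the compounds shown do not separate the two; 3-methoxyphenyl and 2-isopropylphenyl tails would tell them apart. Also open, going by these compounds, is how a tail carrying an amine would behave.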